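Vero cell cytotoxicity across the shared amide series

The compounds below may be only part of what the source reports. "The series", "measured", "known", "first", "only" and "open" are said of these compounds alone.

compound 1 `COC(=O)c1cc(-c2cccc(NC(=O)c3ccc(/C=C/C(=O)c4ccc(C)cc4)cc3)c2)on1`: > 80 ug/mL
compound 2 `CCOC(=O)c1cc(-c2cccc(NC(=O)c3cccc(C(F)(F)F)c3)c2)on1`: "not determined" (no result reported)

In an ADME assay on Vero cells (Chlorocebus sabaeus) for cytotoxicity, read by MTT assay, with a stated time of 72 h (on this read-out higher numbers stand for lower toxicity in this test and lower numbers for higher toxicity in this test), compound 1 gives only a limit of the assay, > 80 ug/mL. For compound 2 this assay holds no result, "not determined" (no result reported). Among the measured compounds shown here, compound 1 therefore sits at the limit of > 80 ug/mL in this assay, at which 1 of the 2 values shown sits, and no step between measured compounds can be read. Compound 3 `COC(=O)c1cc(-c2cccc(NC(=O)c3ccc(/C=C/C(=O)c4cccc(OC)c4)cc3)c2)on1` differs from compound 1 by 3-methoxyphenyl in place of 4-methylphenyl on a carbonyl carbon. In this assay the expected step is a number no higher from compound 1 to compound 3 (the limit leaves the size open), that is, none beyond the usual scatter. Compound 3 is estimated at 80 ug/mL, within 40 ug/mL to 160 ug/mL, with a limit rather than a single number again likely.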

Compound 3, half-maximal cytotoxic concentration: > 100 ug/mL
Compound 3: a limit, no number; the forecaster's own chance of this, stated with the estimate: 75%; middle value at least 1.2-fold (0.09 log units) away from the limit.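

Compound 1 and compound 3 each give only a limit in this assay, so no step can be read between them. Left open is whether 3-methoxyphenyl in place of 4-methylphenyl on a carbonyl carbon changes cytotoxicity at all.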